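A few compounds are considered here, and "the series" means these few. Any claim that something is new, unique, unknown or untested is made for them only; others in the source may bear on it.

Among the compounds with values here, in a functional assay on CCRF-CEM cells (Homo sapiens) for antiproliferative activity, read by MTT assay, with a stated time of 24 h, tested at 25 uM (a higher number here means a weaker effect of the compound at the concentration tested, a lower number a stronger effect), compound 2 `OC(CCn1nc2c(Br)c(Br)c(Br)c(Br)c2n1)c1ccccc1` gives 123%, the higher of the two numbers measured so far; compound 1 `OC(CCn1nc2c(Br)c(Br)c(Br)c(Br)c2n1)c1ccc(F)cc1` gives 104%, and the step of a number 19 percentage points higher from compound 1 to compound 2 (beyond the scatter) is the only measured one. Compound 3 `CC(O)CCn1nc2c(Br)c(Br)c(Br)c(Br)c2n1` differs from compound 2 by methyl in place of phenyl on a saturated chain carbon bound to an oxygen on a saturated carbon and a saturated chain carbon. That single measured step swaps a fluoro for hydrogen on the phenyl and tells nothing about replacing the whole phenyl, so no step beyond the scatter is expected, and a number 11 percentage points lower from compound 2 to compound 3 (beyond the scatter) is the expected change. Compound 3 is therefore estimated at 112%, somewhere between 90% and 135%.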

Compound 3, a percentage reported as activity, at one concentration (the size of the read-out at that concentration, not a potency): 113%
Estimate against measurement, compound 3: 1 percentage points below, within the range that was stated.
By their numbers in this assay, from the lowest: compounds 1, 3 and 2 (each within the scatter of the next, the first and the last beyond it).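

In this assay, swapping an aromatic ring for methyl on this saturated chain carbon gives no step beyond the scatter (a number 10 percentage points lower from compound 2 to compound 3 (within the scatter)) (a number 9 percentage points higher from compound 1 to compound 3 (within the scatter)). At this position, then, methyl does not separate from either phenyl or 4-fluorophenyl, even though the two ring-bearing compounds differ from each other beyond the scatter. Nothing available accounts for this result. Still open, from the compounds shown here alone, is whether an amine, a carboxylic acid or a longer chain on this carbon would give a step beyond the scatter.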